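This account rests on a few compounds, and the source may have more. Where it says the series, first, only, none or still open, it means among the compounds named here.

Compound 1 `COc1nc(-c2ccc(Br)cc2)ccc1[C@@H](c1ccccc1)[C@@](O)(CCN(C)C)c1cccc2ccccc12` in a toxicity assay on Vero cells (Chlorocebus sabaeus) for cytotoxicity; a higher number here means that more compound is tolerated, a lower number that less compound is tolerated: > 50 ug/mL
Compound 2 `COc1nc(-c2ccncc2)ccc1[C@@H](c1ccccc1)[C@@](O)(CCN(C)C)c1cccc2ccccc12` in this assay: > 50 ug/mL
Compound 3 `COc1nc(-c2ccc(C(F)(F)F)cc2)ccc1[C@@H](c1ccccc1)[C@@](O)(CCN(C)C)c1cccc2ccccc12` in this assay: > 50 ug/mL

The reading for compound 1 is a limit of the assay and not a number. The reading for compound 2 is likewise a limit. For compound 3 the reading is a limit as well, so compound 3 stands at the same limit as the two other compounds, namely (the limit of > 50 ug/mL in this assay, at which 3 of the 3 values shown sit).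

Compound 4 `COc1nc(-c2cccc(F)c2)ccc1[C@@H](c1ccccc1)[C@@](O)(CCN(C)C)c1cccc2ccccc12` has not yet been measured in this assay. It differs from compound 3 in one place: 3-fluorophenyl in place of 4-(trifluoromethyl)phenyl on an aromatic carbon. The measured steps that bear on it are a step that the two limits leave unreadable from compound 1 to compound 3 and a step that the two limits leave unreadable from compound 2 to compound 3, and also a step that the two limits leave unreadable from compound 1 to compound 2; none of them has a readable size because every reading sits at the limit of > 50 ug/mL in this assay, at which 3 of the 3 values shown sit. Among the measured compounds shown here, no measured step therefore gives a direction or a size for the change from compound 3 to compound 4, and no step beyond the scatter is expected from it.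

Compound 4 is accordingly expected to sit at the same limit, with an estimate of 60 ug/mL, between 25 ug/mL and 130 ug/mL. The step this estimate means, a step that the limit leaves unreadable from compound 3 to compound 4, is expected to be none beyond the scatter.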

Compound 4, half-maximal cytotoxic concentration: > 50 ug/mL
Compound 4 gave a limit, no number; the forecaster's own chance of this, stated with the estimate: 85%; the middle value lies beyond the limit too.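

In this assay the reading for compound 4 is again a limit and not a number, so its steps from compound 1, compound 2 and compound 3 cannot be read: the limit of > 50 ug/mL in this assay, at which 4 of the 4 values shown sit.

The compounds shown leave open at what concentration any of the four becomes cytotoxic, and whether the aryl groups on the shared core differ at all.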